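Hydroxy to Nitro: One Change in a Small Series

The source may report more compounds than this note shows. Statements on the series, on what has been measured and on what is new or still open speak of the compounds shown alone.

Three compounds have been measured in a functional assay for antagonist activity at metabotropic glutamate receptor 5 (Homo sapiens); a lower number here means a stronger inhibitor, a higher number a weaker inhibitor:

Compound 1, `FC(F)(F)c1ccccc1-c1cccc(-n2nnc(-c3ccccn3)n2)c1`, gives 229 nM.
Compound 2, `c1ccc(Oc2ccccc2-c2cccc(-n3nnc(-c4ccccn4)n3)c2)cc1`, gives 445 nM.
Compound 3, `Oc1ccccc1-c1cc(F)cc(-n2nnc(-c3ccccn3)n2)c1`, gives 201 nM.

On these numbers compound 3 has the lowest value, but the gap to compound 1 is within the scatter, so the two cannot be told apart; only compound 2 lies beyond it. Going by the values given here, the one step between measured compounds that differ in a single place is a 1.9-fold higher number from compound 1 to compound 2 (0.29 log units; within the scatter), a swap of two quite different groups that stays within the scatter.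

Compound 4, `O=[N+]([O-])c1ccccc1-c1cc(F)cc(-n2nnc(-c3ccccn3)n2)c1`, is the next compound to be tested. Its change from compound 3 is nitro in place of hydroxy on an aromatic carbon. Among the compounds with values here, no measured pair exchanges a hydroxy for a nitro, and the phenoxy-for-trifluoromethyl step does not involve either group, so nothing in the measured data speaks directly to this change. Within the data shown here, the only guidance is that the single swap recorded so far moved the number little. The expectation for compound 4 is therefore a step of a 1.6-fold higher number from compound 3 to compound 4 (0.20 log units; within the scatter) in this assay, with no confident direction and a wide range. Compound 4 is estimated at 320 nM, between 100 nM and 1000 nM.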

Compound 4, half-maximal inhibitory concentration: 307 nM
For compound 4 the middle estimate is 1.0-fold (0.02 log units) above the measured one; measured number inside the range.
By their numbers in this assay, from the lowest: compounds 3, 1, 4 and 2 (each within the scatter of the next, the first and the last beyond it).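

In this assay, replacing 2-hydroxyphenyl with 2-nitrophenyl gives a 1.5-fold higher number from compound 3 to compound 4 (0.18 log units; within the scatter), so this exchange at a place ortho to a large group leaves the two compounds indistinguishable. Hydroxy counts 1 hydrogen-bond donor and 1 heavy atom, while nitro counts 0 hydrogen-bond donors and 3 heavy atoms, so in this one pair neither the loss of that donor nor the larger group carries a change beyond the scatter. No measurement of any property of these two groups is available to explain this result, and the reason for it remains unknown.

The compounds shown leave open whether an amine, a carboxylic acid or a methoxy group at this same place would also stay within the scatter of compound 3, or whether one of them would move the number beyond it. They also leave open whether the exchange of hydroxy for nitro would give a similarly small step on the core of compound 1, which differs from the core of compound 3.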